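This account rests on a few compounds, and the source may have more. Where it says the series, first, only, none or still open, it means among the compounds named here.

Measured compounds in an assay on isolated protein for inhibition of DNA topoisomerase 1 (Homo sapiens), with a stated time of 30 min, tested at 100 uM; a higher number here means more inhibition at the concentration tested (going by the name of the read-out), a lower number less inhibition:
Compound 1 `O=C(/C=C/c1ccccc1F)Nc1ccc(CC2=CC(=O)OC2)cc1` gives 11.7% in this assay.
Compound 2 `C=C1OC(=O)C=C1Cc1ccc(NC(=O)/C=C/c2ccccc2F)cc1` gives 44.6% in this assay.
Compound 3 `O=C(/C=C/c1ccc(F)cc1)Nc1ccc(CC2=CC(=O)OC2)cc1` gives 12.1% in this assay.

Compound 4 `C=C1OC(=O)C=C1Cc1ccc(NC(=O)/C=C/c2ccc(F)cc2)cc1` has not yet been measured in this assay.

Compound 1 and compound 2 differ in a single spot: a group of 7 heavy atoms (5 carbon, 2 oxygen; one five-membered non-aromatic ring with 1 hetero atom) in place of a group of 6 heavy atoms (4 carbon, 2 oxygen; one five-membered non-aromatic ring with 1 hetero atom), on a saturated chain carbon bound to an aromatic carbon. That one change made a number 32.9 percentage points higher from compound 1 to compound 2 (beyond the scatter), the only step among these compounds that stands out from the scatter. Compound 1 and compound 3 share everything but their cores, and the difference between the two cores is 4-fluorophenyl in place of 2-fluorophenyl on a double-bonded chain carbon bound to a double-bonded chain carbon; it made a number 0.4 percentage points higher from compound 1 to compound 3 (within the scatter), so the two cores behave alike as far as these two numbers show.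

Compound 4 is related to compound 3 exactly as compound 2 is related to compound 1: a group of 7 heavy atoms (5 carbon, 2 oxygen; one five-membered non-aromatic ring with 1 hetero atom) in place of a group of 6 heavy atoms (4 carbon, 2 oxygen; one five-membered non-aromatic ring with 1 hetero atom), on a saturated chain carbon bound to an aromatic carbon. The place is the same in both cases, a saturated chain carbon bound to an aromatic carbon, so this is the same change, made on the core of compound 3 instead of the core of compound 1.

The step from compound 3 to compound 4 is therefore expected at about a number 29.9 percentage points higher from compound 3 to compound 4 (beyond the scatter), close beside the earlier a number 32.9 percentage points higher from compound 1 to compound 2 (beyond the scatter). This expectation rests on a single earlier instance of the change and on the fact that compound 1 and compound 3 start from nearly the same level, because a number 0.4 percentage points higher from compound 1 to compound 3 (within the scatter) lies within the scatter. Among the compounds with values here, with only one precedent, a wide range is kept.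

Compound 4 is estimated at 42%, expected to fall between 22% and 62%.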

Compound 4, a percentage reported as inhibition, at one concentration (the size of the read-out at that concentration, not a potency): 94.1%
For compound 4 the middle estimate is 52.1 percentage points below the measured one; measured number outside the range, above it.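

In this assay the exchange of the ring group gave a number 82 percentage points higher from compound 3 to compound 4 (beyond the scatter) and so went the same way as on the core of compound 1, but its size did not carry over: the same change on two cores in this assay, a number 32.9 percentage points higher (beyond the scatter) from compound 1 to compound 2 and a number 82 percentage points higher (beyond the scatter) from compound 3 to compound 4, 49.1 percentage points apart, beyond the scatter of two such steps. Seen from the other side, 4-fluorophenyl in place of 2-fluorophenyl gave a number 49.5 percentage points higher from compound 2 to compound 4 (beyond the scatter) when the larger ring group was present, yet made no step beyond the scatter with the smaller ring group: the same change on two cores in this assay, a number 0.4 percentage points higher (within the scatter) from compound 1 to compound 3 and a number 49.5 percentage points higher (beyond the scatter) from compound 2 to compound 4, 49.1 percentage points apart, beyond the scatter of two such steps. In these four compounds the two changes therefore do not simply add up, so the earlier step gave the direction on the new core but not a dependable size, and the numbers do not show why the changes depend on each other or whether the same would happen on any other core.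

Still open, going by these compounds, is whether this dependence is specific to fluorine, or whether it would also appear with a plain phenyl ring or with a phenyl ring carrying chlorine or a methoxy group instead. On these data alone, it is also open how the read-out would respond to a larger replacement at the same place, such as a ring group carrying an amine or a carboxylic acid.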